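Adding a second trifluoromethyl to compound 3

A few compounds are considered here, and "the series" means these few. Any claim that something is new, unique, unknown or untested is made for them only; others in the source may bear on it.

The series shares the core of compound 1 `COc1cc(NC(C)CCCNC(=O)NNC(=O)Nc2ccc(Cl)cc2)c2ncccc2c1` and is read in a functional assay on MIA PaCa-2 cells (Homo sapiens) for inhibition, read by MTT assay, with a stated time of 72 h; on this read-out higher numbers stand for weaker inhibition and lower numbers for stronger inhibition. Compound 1 reaches only a limit of the assay, >= 250000 nM. Compound 2 `COc1cc(NC(C)CCCNC(=O)NNC(=O)Nc2cccc(F)c2)c2ncccc2c1` gives 69000 nM. Within the data shown here, compound 3 `COc1cc(NC(C)CCCNC(=O)NNC(=O)Nc2cccc(C(F)(F)F)c2)c2ncccc2c1` gives 5600 nM, the lowest number measured so far and the strongest inhibition in the set.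

Compound 4 `COc1cc(NC(C)CCCNC(=O)NNC(=O)Nc2cc(C(F)(F)F)cc(C(F)(F)F)c2)c2ncccc2c1` differs from compound 3 in one place, with trifluoromethyl in place of hydrogen on an aromatic carbon, meta to a trifluoromethyl group: trifluoromethyl in place of hydrogen on an aromatic carbon.

The closest measured precedent is a 12-fold lower number from compound 2 to compound 3 (1.09 log units; beyond the scatter), where trifluoromethyl replaces fluoro on an aromatic carbon. The other two steps, an at least 3.6-fold lower number from compound 1 to compound 2 (0.55 log units; beyond the scatter) and an at least 44-fold lower number from compound 1 to compound 3 (1.64 log units; beyond the scatter), point the same way, but both start from a limit and so give no exact size. Among the measured compounds shown here, none of the measured steps adds a second group to the phenyl ring, so the size of these steps cannot simply be carried over.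

Given a 12-fold lower number from compound 2 to compound 3 (1.09 log units; beyond the scatter), a further fall in the number is expected, though a smaller one than in that step. The expected change is a 2.2-fold lower number from compound 3 to compound 4 (0.35 log units; beyond the scatter). Compound 4 is estimated at 2500 nM, with an expected range of 600 nM to 10000 nM.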

Compound 4, half-maximal inhibitory concentration: 20000 nM
The estimate for compound 4 lay 8.0-fold (0.90 log units) below the measured number; measured number above the stated range.
By their numbers in this assay, from the lowest: compound 3; then compound 4; then compound 2. At a limit, above all of these: compound 1.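

Working notes on the phenyl ring. In this assay, placing trifluoromethyl on the aromatic carbon meta to a trifluoromethyl group gives a 3.6-fold higher number from compound 3 to compound 4 (0.55 log units; beyond the scatter) and so runs opposite to the fall seen when trifluoromethyl replaced fluoro. The earlier steps shown here only exchanged one ring substituent for another, whereas this one adds a group to a ring that already carries trifluoromethyl, and it shows that the gain from that group does not build up when a second copy enters at this place. Nothing among the data shown gives a cause for this reversal.

As far as these compounds go, it remains open whether the rise belongs to trifluoromethyl itself or to any group at this place, which a fluoro, a methoxy, an amine or a carboxylic acid on the same aromatic carbon would help to separate. Also open is whether the same reversal holds with a longer chain between the shared core and the urea-type end of the molecule, since every compound shown carries the same chain.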